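Replacing the 1-methyl-1H-pyrazol-4-yl group of compound 2

A few compounds are considered here, and "the series" means these few. Any claim that something is new, unique, unknown or untested is made for them only; others in the source may bear on it.

In a functional assay on HeLa cells (Homo sapiens) for antiproliferative activity, read by MTT assay, with a stated time of 72 h (a lower number here means a stronger inhibitor, a higher number a weaker inhibitor), compound 2 (`Cn1cc(-c2nn(Cc3ccc(C(=O)NC4CCCC4)cc3)c(=O)c3ccccc23)cn1`) gives 16700 nM and compound 3 (`Cn1cc(-c2nn(Cc3ccc(C(=O)NC4CC(C)(C)N([O])C(C)(C)C4)cc3)c(=O)c3ccccc23)cn1`) gives 27700 nM, two numbers that lie within the scatter of each other. Within the data shown here, the only other reading is that of compound 1 (`Cc1noc(C)c1-c1nn(Cc2ccc(C(=O)NC3CC3)cc2)c(=O)c2ccccc12`), whose > 100000 nM is a limit and not a number.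

Compound 4 (`Cc1noc(C)c1-c1nn(Cc2ccc(C(=O)NC3CCCC3)cc2)c(=O)c2ccccc12`) has 3,5-dimethyl-1,2-oxazol-4-yl in place of 1-methyl-1H-pyrazol-4-yl on an aromatic carbon of the shared core (3,5-dimethyl-1,2-oxazol-4-yl in place of 1-methyl-1H-pyrazol-4-yl on an aromatic carbon), and the rest of compound 2 stays as it is. Among the measured compounds shown here, the single measured step, a 1.7-fold higher number from compound 2 to compound 3 (0.22 log units; within the scatter), changes the group on the amide-type nitrogen and stays within the scatter. It does not touch the place of the new change, so no measured step sizes this swap directly.

The nearest hint comes from compound 1, which carries the same 3,5-dimethyl-1,2-oxazol-4-yl group but a different group on the amide nitrogen, and whose reading of > 100000 nM is a limit. On that slender basis, the step expected in this assay is small and towards a higher number: a 2.1-fold higher number from compound 2 to compound 4 (0.32 log units; beyond the scatter), as estimated. For compound 4 the estimate is 35000 nM, with the measurement expected between 12000 nM and 100000 nM.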

Compound 4, half-maximal inhibitory concentration: > 100000 nM
Compound 4 ended at the assay's limit; the forecaster's own chance of this, stated with the estimate: 25%; at least 2.8-fold (0.45 log units) between middle value and limit.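

In this assay, the change at this position now has a readable size of its own, with the cyclopentyl group on the amide nitrogen held fixed: an at least 5.9-fold higher number from compound 2 to compound 4 (0.77 log units; beyond the scatter). Among these compounds, the aromatic carbon next to the ring nitrogen is thus a place where the reading responds to the group it carries, and 3,5-dimethyl-1,2-oxazol-4-yl gives a weaker inhibitor here than 1-methyl-1H-pyrazol-4-yl; the only earlier step, a 1.7-fold higher number from compound 2 to compound 3 (0.22 log units; within the scatter), lay on the amide-type nitrogen. Compound 1 could not show this on its own, as it differs from compound 2 in two places, and the step from compound 1 to compound 4 cannot be read, with each of the two compounds ending at a limit and not at a number: the limit of > 100000 nM in this assay, at which 2 of the 4 values shown sit.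

The compounds shown therefore leave open how far beyond the limit compound 4 lies, and whether cyclopropyl and cyclopentyl differ at all alongside 3,5-dimethyl-1,2-oxazol-4-yl. Also open, on these data alone, is how a phenyl ring, or a pyrazol-4-yl ring with no methyl group, would read at this carbon.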